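Swapping an allyl for a benzyl on a cytotoxicity core

The source may hold more compounds than are shown below. What is called first, only, known or untested is meant among the compounds shown, and "the series" means these compounds.

Compounds with a measured number so far:
Compound 1, `COC(=O)C1C(=O)C(C(=O)OC)[C@H](c2ccccn2)N(CCCCCCCC(=O)O)[C@@H]1c1ccccn1`, gives 33.8 uM.
Compound 2, `C=CCN1[C@H](c2ccc([N+](=O)[O-])cc2)C(C(=O)OC)C(=O)C(C(=O)OC)[C@@H]1c1ccc([N+](=O)[O-])cc1`, gives 50.3 uM.
Compound 3, `C[C@@H]1CC2(C[C@H](C)N1)C(=O)N(CCO)C(=O)N2Cc1ccccc1`, reaches only the assay limit of > 100 uM, which is a limit and not a number.

All of these were tested in an ADME assay on J774.1 cells (Mus musculus) for cytotoxicity, with a stated time of 48 h; a higher number here means that more compound is needed for the effect, a lower number that less compound is needed. Within the data shown here, compound 2 and compound 1 are the only two compounds here with a number, and the two numbers lie within the usual scatter of each other, so no difference between them can be read from the data. Compound 3 adds no number, since its value is a limit; (the limit of > 100 uM in this assay, at which 1 of the 3 values shown sits).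

Compound 4, `COC(=O)C1C(=O)C(C(=O)OC)[C@H](c2ccc([N+](=O)[O-])cc2)N(Cc2ccccc2)[C@@H]1c1ccc([N+](=O)[O-])cc1`, has not yet been measured. It differs from compound 2 in one place: phenyl in place of vinyl on a saturated chain carbon bound to an amine nitrogen in a ring. Among the measured compounds shown here, no step between two measured compounds covers a change of this kind, so there is nothing in the data to point to a rise or a fall. The expectation is therefore a step from compound 2 to compound 4 of about a 1.1-fold lower number from compound 2 to compound 4 (0.05 log units; within the scatter), meaning no change beyond the scatter. On that basis compound 4 is estimated at 45 uM in this assay, with a range from 18 uM to 110 uM.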

Compound 4, concentration for half-maximal effect: 18.4 uM
The estimate for compound 4 lay 2.4-fold (0.39 log units) above the measured number; measured number inside the range.
By their numbers in this assay, from the lowest: compounds 4, 1 and 2 (each within the scatter of the next, the first and the last beyond it). At a limit, above all of these: compound 3.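

Among these compounds, until now, no two measured compounds differed in only one place, so no single change could be judged. In this assay there is now one step to read, a 2.7-fold lower number from compound 2 to compound 4 (0.44 log units; beyond the scatter), for phenyl in place of vinyl on a saturated chain carbon bound to an amine nitrogen in a ring, or, cut one bond further out, allyl to benzyl. This shows that what is attached at this place can shift the amount of compound needed for the effect, with less needed for the benzyl, although the step is modest and rests on one pair, and no measurement given here bears on why it arises.

The compounds shown leave open whether the aromatic ring of the benzyl matters here, since a cyclohexylmethyl group, which keeps a six-membered ring without being aromatic, or a plain ethyl chain at the same place would help to separate the ring from the simple size of the group. From the compounds shown here alone, it also remains open whether the same change from allyl to benzyl would give a similar step on a core carrying other ring groups.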